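A 2-Nitrophenyl Exchange in a Closely Matched Series

The source may report more compounds than this note shows. Statements on the series, on what has been measured and on what is new or still open speak of the compounds shown alone.

In a functional assay on HCT-116 cells (Homo sapiens) for antiproliferative activity, read by MTT assay, with a stated time of 72 h (a lower number here means a stronger inhibitor, a higher number a weaker inhibitor), compound 1 `Cc1ccc(N2CCN(C(=S)SCc3ccc4nc(N)nc(N)c4c3)CC2)cc1` gives 5510 nM while compound 2 `Nc1nc(N)c2cc(CSC(=S)N3CCN(c4ccccc4Cl)CC3)ccc2n1` gives 5490 nM and compound 3 `Nc1nc(N)c2cc(CSC(=S)N3CCN(c4ccc(F)cc4F)CC3)ccc2n1` gives 5150 nM in a closely matched trio. Compound 3 therefore stands level with the other two, within the scatter of each, and the numbers set no order among the three. Compound 4 `Nc1nc(N)c2cc(CSC(=S)N3CCN(c4ccccc4[N+](=O)[O-])CC3)ccc2n1` keeps the shared core and differs from compound 3 at one place, with 2-nitrophenyl in place of 2,4-difluorophenyl on an amine nitrogen in a ring. Three measured steps at that same place bear on this exchange. They are a 1.0-fold lower number from compound 1 to compound 2 (0.00 log units; within the scatter) together with a 1.1-fold lower number from compound 1 to compound 3 (0.03 log units; within the scatter) and a 1.1-fold lower number from compound 2 to compound 3 (0.03 log units; within the scatter) and none of them leaves the scatter. For the measured compounds named here, the 4-methylphenyl, 2-chlorophenyl and 2,4-difluorophenyl compounds thus give matching numbers, but no 2-nitrophenyl compound has yet been measured, so the expectation rests on these three alone. The estimated step in this assay is a 1.0-fold higher number from compound 3 to compound 4 (0.01 log units; within the scatter) and no shift in either direction beyond the scatter is expected. Compound 4 is expected near 5300 nM with an estimated range from 2500 nM to 11000 nM for its measurement.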

Compound 4, half-maximal inhibitory concentration: 5520 nM
Estimate against measurement, compound 4: 1.0-fold (0.02 log units) below; the range from low to high includes it.
By their numbers in this assay, from the lowest: compounds 3, 2, 1 and 4 (each within the scatter of the next).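

In this assay, the step of a 1.1-fold higher number from compound 3 to compound 4 (0.03 log units; within the scatter) shows that this position on the amine nitrogen in a ring also tolerates a 2-nitrophenyl group, which has 2 hydrogen-bond acceptors where 2,4-difluorophenyl has 0, without leaving the scatter. The direct exchange of chloro for nitro on an aromatic carbon, a 1.0-fold higher number from compound 2 to compound 4 (0.00 log units; within the scatter), and the change from 4-methylphenyl, a 1.0-fold higher number from compound 1 to compound 4 (0.00 log units; within the scatter), are also within the scatter, so all four compounds remain level and the numbers set no order among them. Nothing available here accounts for this flat response, and no measurement of any property of these groups accompanies the numbers.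

On these data alone, all four compounds carry a substituted phenyl ring at this place, so it remains open whether an amine or a carboxylic acid on that ring would move the number beyond the scatter. As far as these compounds go, it is equally open whether an unsubstituted alkyl chain in place of the ring, or a change elsewhere on the shared core, would break the level seen in this assay.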